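This account rests on a few compounds, and the source may have more. Where it says the series, first, only, none or still open, it means among the compounds named here.

In a functional assay on HOP-62 cells (Homo sapiens) for inhibition (a higher number here means a weaker inhibitor of growth, a lower number a stronger inhibitor of growth), compound 1 `COc1cc(/C=C/C(=O)c2cccc(-n3cc(-c4ccccc4)[nH]c3=O)c2)ccc1O` gives 1480 nM, and compound 2 `COc1cc(/C=C/C(=O)c2cccc(-n3cc(-c4ccccc4)[nH]c3=O)c2)cc(OC)c1OC` gives 4120 nM. Compound 2 thus has the higher of the two numbers, making it the weaker inhibitor of growth, and the gap lies beyond the usual scatter. Compound 3 `COc1ccc(-c2cn(-c3cccc(C(=O)/C=C/c4cc(OC)c(OC)c(OC)c4)c3)c(=O)[nH]2)cc1` differs from compound 2 in one place: methoxy in place of hydrogen on an aromatic carbon, with methoxy in place of hydrogen on an aromatic carbon. Within the data shown here, no measured pair of compounds shows this change, so the expectation is tentative. The expected step of a 1.4-fold lower number from compound 2 to compound 3 (0.14 log units; within the scatter) is small, toward a lower number and within the scatter. Compound 3 is estimated at 3000 nM, with an expected range from 1000 nM to 9000 nM.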

Compound 3, concentration for 50% growth inhibition: 5910 nM
Beside the measured number, compound 3's estimate is 2.0-fold (0.29 log units) below it; the measured number falls inside the stated range.
By their numbers in this assay, from the lowest: compound 1; then compounds 2 and 3 (each within the scatter of the next).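

In this assay the change from phenyl to 4-methoxyphenyl gives a 1.4-fold higher number from compound 2 to compound 3 (0.16 log units; within the scatter) and so cannot be told apart from repeat-measurement noise. This position, para to a large group, therefore accepts a methoxy with no clear loss or gain, something compound 1 and compound 2 could not show, as both carry the plain phenyl. Nothing measured here offers an explanation for this result. Still open, as far as these compounds go, is how an amine or a carboxylic acid at this position would behave, or a longer chain in place of the methoxy.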